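Compound 3 to compound 4: exchange of the aryl group

The source may hold more compounds than are shown below. What is called first, only, known or untested is meant among the compounds shown, and "the series" means these compounds.

In a physicochemical assay for permeability, using PAMPA (a lower number here means that the compound crosses the layer more slowly, a higher number that the compound crosses the layer faster), compound 3 `Cc1ccc(-c2nc(CN3CCC(C(=O)NCCCN4C[C@H](C)C[C@H](C)C4)CC3)c(C)o2)cc1` gives 274 10^-6 cm/s and compound 1 `Cc1oc(-c2c(C)c(C)c(C)c(C)c2C)nc1CN1CCC(C(=O)NCCCN2C[C@H](C)C[C@H](C)C2)CC1` gives 455 10^-6 cm/s so these two stand within the scatter of each other. Compound 2 `Cc1oc(-c2ccc(Cl)cc2)nc1CN1CCC(C(=O)NCCCN2C[C@H](C)C[C@H](C)C2)CC1` gives > 635 10^-6 cm/s as a limit of the assay and not a number.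

Compound 4 `COc1cccc(Cl)c1-c1nc(CN2CCC(C(=O)NCCCN3C[C@H](C)C[C@H](C)C3)CC2)c(C)o1` carries 2-chloro-6-methoxyphenyl in place of 4-methylphenyl on an aromatic carbon next to the ring nitrogen and next to the ring oxygen. Three measured steps change the group on this same carbon. Two stay within the scatter: a 1.7-fold lower number from compound 1 to compound 3 (0.22 log units; within the scatter) and an at least 1.3-fold higher number from compound 1 to compound 2 (0.14 log units; that floor lies within the scatter) with only a floor known for the second. Only an at least 2.3-fold lower number from compound 2 to compound 3 (0.36 log units; beyond the scatter) goes beyond the scatter and that size is a floor as well.

Given a 1.7-fold lower number from compound 1 to compound 3 (0.22 log units; within the scatter) on the same carbon no step beyond the scatter is expected in this assay for this exchange. The estimated step is a 1.3-fold higher number from compound 3 to compound 4 (0.11 log units; within the scatter) on that basis. For compound 4 the expected value is 350 10^-6 cm/s with an estimated range from 170 10^-6 cm/s to 640 10^-6 cm/s in this series.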

Compound 4, apparent permeability: 51 10^-6 cm/s
For compound 4 the middle estimate is 6.9-fold (0.84 log units) above the measured one, outside the stated range (below it).
By their numbers in this assay, from the lowest: compound 4; then compounds 3 and 1 (each within the scatter of the next). At a limit, above all of these: compound 2.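

In this assay, the aryl group on this carbon can move the number well beyond the scatter: a 5.4-fold lower number from compound 3 to compound 4 (0.73 log units; beyond the scatter), and an 8.9-fold lower number from compound 1 to compound 4 (0.95 log units; beyond the scatter). Earlier, compound 1 and compound 3 stood within the scatter of each other, so having substituents on the aryl ring does not by itself go with a low number: 2,3,4,5,6-pentamethylphenyl in compound 1 goes against any such pattern, and 2-chloro-6-methoxyphenyl stands apart from it. Only a floor is known for the third step, an at least 12-fold lower number from compound 2 to compound 4 (1.09 log units; beyond the scatter), which rests on a limit of the assay and not a number: the limit of > 635 10^-6 cm/s in this assay, at which 1 of the 4 values shown sits.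

The compounds shown do not separate the contribution of the chloro from that of the methoxy within 2-chloro-6-methoxyphenyl. On these data alone, how an aryl group bearing only one of these, or bearing an amine or a carboxylic acid, would read here remains open.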